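The source may hold more compounds than are shown below. What is called first, only, known or untested is meant among the compounds shown, and "the series" means these compounds.

For the measured compounds named here, the account centres on compound 2 `COc1cc(OCc2cccc(COc3ccccc3)c2)c2cc(-c3cn4nc(OC)sc4n3)oc2c1`, one of three compounds measured in an ADME assay on microsomes from liver (Rattus norvegicus) for metabolic stability, with a stated time of 10 min; on this read-out lower numbers stand for a less stable compound and higher numbers for a more stable compound. In this assay compound 2 gives 64%, the second highest of the three numbers. Compound 3 `COc1nn2cc(-c3cc4ccc(OCc5ccccc5)cc4o3)nc2s1` stands nearest to it; in this assay compound 3 gives 68%, which lies within the scatter of the number for compound 2, so the two cannot be told apart. Compound 1 `COc1nn2cc(-c3cc4ccc(OC)c(OC)c4o3)nc2s1` stands furthest away; in this assay compound 1 gives 3%, far beyond the scatter and well under the number for compound 2. Compound 4 `COc1cc(OCc2cccc(Oc3ccccc3)c2)c2cc(-c3cn4nc(OC)sc4n3)oc2c1` has not yet been measured in this assay. It differs from compound 2 in one place: phenoxy in place of phenoxymethyl on an aromatic carbon, meta to a large group. Going by the values given here, no pair of measured compounds that differ in one place is available, so nothing measured shows what this exchange does in this assay. The estimate starts from compound 2 and its number of 64%, and expects a step from compound 2 to compound 4 of a number 1 percentage points higher from compound 2 to compound 4 (within the scatter), none beyond the scatter. Compound 4 is thus estimated at 65% in this assay, with a range from 45% to 85%.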

Compound 4, percent of the compound remaining: 42%
For compound 4 the middle estimate is 23 percentage points above the measured one, and the stated range ends above it.
By their numbers in this assay, from the lowest: compound 1; then compound 4; then compounds 2 and 3 (each within the scatter of the next).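

With this result, the position on an aromatic carbon, meta to a large group, has its first readable exchange in this assay: phenoxy in place of phenoxymethyl gives a number 22 percentage points lower from compound 2 to compound 4 (beyond the scatter). The earlier compounds shown here offered no pair differing in one place, whereas this pair shows that a small exchange here can move the number beyond the scatter: phenoxymethyl has 8 heavy atoms and phenoxy 7, and each has one six-membered aromatic ring of carbon only and 1 hydrogen-bond acceptor. No measurement at hand accounts for the step.

The compounds shown leave open how a longer chain such as phenoxyethyl, or an amine or a carboxylic acid in the same place, would stand in this assay. They also leave open whether the same exchange would give a similar step on another core, as this single pair shares one core and compound 1 and compound 3 each differ from compound 2 in more than one place.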